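Swapping the pyrrole for a pyridine on the exocyclic arm

A few compounds are considered here, and "the series" means these few. Any claim that something is new, unique, unknown or untested is made for them only; others in the source may bear on it.

Measured compounds:
- compound 1 `CCOC(=O)C1=C(Nc2ccccc2)S/C(=C\c2cccc(C(=O)O)c2)C1=O`: 50.6%
- compound 2 `CCOC(=O)C1=C(Nc2ccccc2)S/C(=C\c2cc[nH]c2)C1=O`: 19.5%

In a functional assay on JAR cells (Homo sapiens) for inhibition, read by MTT assay, with a stated time of 72 h, tested at 10 uM (on this read-out lower numbers stand for less inhibition and higher numbers for more inhibition at the one concentration tested (going by the name of the read-out)), compound 1 gives 50.6% and compound 2 gives 19.5%. Compound 2 thus stands lowest of the two numbers; its nearest neighbour is compound 1, and the step of a number 31.1 percentage points lower from compound 1 to compound 2 (beyond the scatter) lies beyond the scatter. Compound 3 `CCOC(=O)C1=C(Nc2ccccc2)S/C(=C\c2cccnc2)C1=O` has not yet been measured in this assay. It differs from compound 2 by pyridin-3-yl in place of 1H-pyrrol-3-yl on a double-bonded chain carbon bound to a double-bonded ring carbon. Going by the values given here, the only measured step bearing on this position is a number 31.1 percentage points lower from compound 1 to compound 2 (beyond the scatter), a large fall. The group entering here is neither the one that left in that step nor the one that came in, so the direction is uncertain; a moderate rise from compound 2 is expected, a number 12.5 percentage points higher from compound 2 to compound 3 (beyond the scatter). For compound 3 the estimate in this assay is 32%, with a range from 12% to 55%.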

Compound 3, a percentage reported as inhibition, at one concentration (the size of the read-out at that concentration, not a potency): 32.1%
Compound 3: the middle estimate sits 0.1 percentage points below what was measured; the measured number falls inside the stated range.
By their numbers in this assay, from the lowest: compound 2; then compound 3; then compound 1.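

In this assay the exchange of 1H-pyrrol-3-yl for pyridin-3-yl gives a number 12.6 percentage points higher from compound 2 to compound 3 (beyond the scatter) and so shows that the low number of the pyrrole is not shared by both nitrogen-bearing aromatic rings at this place. Pyridin-3-yl in place of 3-carboxyphenyl still gives a number 18.5 percentage points lower from compound 1 to compound 3 (beyond the scatter) and leaves the pyridine compound in the middle, so the three aromatic groups on the double-bonded chain carbon give three separate levels. Nothing available explains this order.

Whether the carboxylic acid itself accounts for the high number of compound 1 remains open, and a plain phenyl ring or a methyl ester in its place would test this. Also open, as far as these compounds go, is how pyridin-4-yl, or an amine on the pyridine ring, would read here.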